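Working notes: pyridin-3-yl in place of 3-carbamoylphenyl

The source may hold more compounds than are shown below. What is called first, only, known or untested is meant among the compounds shown, and "the series" means these compounds.

Measured in an ADME assay (liver) for metabolic stability, with Liver microsome (Homo sapiens) as the target, using microsomes and NADPH, with a stated time of 30 min, tested at 1 uM; on this read-out higher numbers stand for fast clearance and lower numbers for slow clearance:
- Compound 1 `CCn1cc(-c2cc(C(O)(C(F)(F)F)C(F)(F)F)cnc2N2CCN(S(=O)(=O)c3ccc(N)nc3)CC2)cn1`: 20 mL.min-1.g-1
- Compound 2 `NC(=O)c1cccc(-c2cc(C(O)(C(F)(F)F)C(F)(F)F)cnc2N2CCN(S(=O)(=O)c3ccc(N)nc3)CC2)c1`: 17 mL.min-1.g-1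

Compound 2 gives 17 mL.min-1.g-1, which lies within the scatter of compound 1. Compound 3 `Nc1ccc(S(=O)(=O)N2CCN(c3ncc(C(O)(C(F)(F)F)C(F)(F)F)cc3-c3cccnc3)CC2)cn1` carries pyridin-3-yl in place of 3-carbamoylphenyl on an aromatic carbon. Among the compounds with values here, the one measured step at this place, a 1.2-fold lower number from compound 1 to compound 2 (0.07 log units; within the scatter), brought in 3-carbamoylphenyl in place of 1-ethyl-1H-pyrazol-4-yl and stayed within the scatter. No change beyond the scatter is therefore expected in this assay, and the estimated step is a 1.1-fold higher number from compound 2 to compound 3 (0.02 log units; within the scatter). The estimate for compound 3 is 18 mL.min-1.g-1, with an expected range of 10 mL.min-1.g-1 to 32 mL.min-1.g-1.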

Compound 3, intrinsic clearance in microsomes: 17 mL.min-1.g-1
Estimate against measurement, compound 3: 1.1-fold (0.02 log units) above, within the range that was stated.
By their numbers in this assay, from the lowest: compounds 2, 3 and 1 (each within the scatter of the next).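

In this assay, a third group at this aromatic carbon stays within the scatter, both against 3-carbamoylphenyl (no change at the digits printed from compound 2 to compound 3 (within the scatter)) and against 1-ethyl-1H-pyrazol-4-yl (a 1.2-fold lower number from compound 1 to compound 3 (0.07 log units; within the scatter)). Pyridin-3-yl has fewer heavy atoms than 3-carbamoylphenyl and 0 hydrogen-bond donors instead of 1, yet the read-out shows no step beyond the scatter. Across these three aromatic groups, the position has not separated the compounds.

Going by these compounds, whether a carboxylic acid, a morpholine or a plain methyl here would give a step beyond the scatter remains open. No measurement shown explains why these three compounds read alike.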